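The source may report more compounds than this note shows. Statements on the series, on what has been measured and on what is new or still open speak of the compounds shown alone.

Compound 3 `NCCCC[C@H](NC(=O)CN(c1nc(Cl)nc2[nH]cnc12)C1CC1)C(=O)O` belongs to a small set of three compounds built on one shared core. In a functional assay on the whole organism (Tail, strain ICR) with Mus musculus as the target, in the tail flick test, with a stated time of 90 min, at a dose of 25 umol/kg by the oral route (on this read-out lower numbers stand for a weaker effect and higher numbers for a stronger effect at the one dose given), compound 3 gives 28.8%. Its nearest companion is compound 1 `N=C(N)NCCC[C@H](NC(=O)CN(c1nc(Cl)nc2[nH]cnc12)C1CC1)C(=O)O`, which in this assay gives 27.6%, the two numbers being separated by a number 1.2 percentage points higher from compound 1 to compound 3 (within the scatter). Compound 2 `O=C(O)CNC(=O)CN(c1nc(Cl)nc2[nH]cnc12)C1CC1` in this assay gives 32.3%, separated from compound 3 by a number 3.5 percentage points lower from compound 2 to compound 3 (within the scatter). All three numbers lie within the scatter of one another, so none of the three can be called stronger or weaker than the others.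

Compound 4 `CC(C)[C@H](NC(=O)CN(c1nc(Cl)nc2[nH]cnc12)C1CC1)C(=O)O` has not yet been measured. It differs from compound 3 in one place: isopropyl in place of 4-aminobutyl on a saturated chain carbon bound to an amide-type nitrogen and a carbonyl carbon. The step that bears most directly on this change is the one in which 4-aminobutyl entered in place of hydrogen at the same place, a number 3.5 percentage points lower from compound 2 to compound 3 (within the scatter); the steps of a number 4.7 percentage points higher from compound 1 to compound 2 (within the scatter) and a number 1.2 percentage points higher from compound 1 to compound 3 (within the scatter) at or near this carbon likewise stayed within the scatter. Because a number 3.5 percentage points lower from compound 2 to compound 3 (within the scatter) stayed within the scatter, compound 4 is expected to show a number 1.2 percentage points higher from compound 3 to compound 4 (within the scatter), that is no step beyond the scatter. Compound 4 is therefore estimated to give 30%, within a range from 18% to 42%.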

Compound 4, a percentage reported as activity, at one dose (the size of the read-out at that dose, not a potency): 30.3%
Beside the measured number, compound 4's estimate is 0.3 percentage points below it; low and high end bracket the measured number.
By their numbers in this assay, from the lowest: compounds 1, 3, 4 and 2 (each within the scatter of the next).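

At the saturated chain carbon bound to an amide-type nitrogen and a carbonyl carbon, compound 4 brings the first all-carbon group, and in this assay this leaves the read-out within the scatter of both 4-aminobutyl, a number 1.5 percentage points higher from compound 3 to compound 4 (within the scatter), and hydrogen, a number 2 percentage points lower from compound 2 to compound 4 (within the scatter). The group carried by compound 1 gives the same picture, a number 2.7 percentage points higher from compound 1 to compound 4 (within the scatter), so the nitrogen atoms of the earlier side chains are not needed to keep the read-out in this band. No measured evidence gives a reason for this flat picture.

Still open, on these data alone, is whether a benzyl group or a side-chain carboxylic acid on this carbon would produce a step beyond the scatter. All four numbers also come from a single dose and time, so they show the size of the effect at that dose and leave open how the compounds would compare at any other dose.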